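Swapping Bromo for Nitro on a Shared Core

The source may hold more compounds than are shown below. What is called first, only, known or untested is meant among the compounds shown, and "the series" means these compounds.

Compound 1 `C=CC(=O)N1C(=O)CC(c2ccc(C)cc2)Sc2ccccc21` gives 37300 nM in a functional assay on NB-4 cells (Homo sapiens) for cytotoxicity, read by CCK-8 assay, with a stated time of 24 h; a lower number here means a stronger inhibitor, a higher number a weaker inhibitor.
Compound 2 `C=CC(=O)N1C(=O)CC(c2ccc(Br)cc2)Sc2ccccc21` gives 59400 nM in this assay.

Among the compounds with values here, compound 2 stands highest of the two numbers, its only neighbor being compound 1; the step of a 1.6-fold higher number from compound 1 to compound 2 (0.20 log units; within the scatter) shows that exchanging one para group for another left the number within the usual scatter. Compound 3 `C=CC(=O)N1C(=O)CC(c2ccc([N+](=O)[O-])cc2)Sc2ccccc21` differs from compound 2 in one place: nitro in place of bromo on an aromatic carbon. Within the data shown here, the single measured step bears on this change only loosely, since it shows how much the number moved when the same position was altered. A step of no size beyond the scatter is therefore expected, so a 1.2-fold lower number from compound 2 to compound 3 (0.07 log units; within the scatter) is the estimate. Compound 3 is expected to give 50000 nM, from 20000 nM to 125000 nM.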

Compound 3, half-maximal inhibitory concentration: 37700 nM
The estimate for compound 3 lay 1.3-fold (0.12 log units) above the measured number; low and high end bracket the measured number.
By their numbers in this assay, from the lowest: compounds 1, 3 and 2 (each within the scatter of the next).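

Nitro in place of bromo gave a 1.6-fold lower number from compound 2 to compound 3 (0.20 log units; within the scatter) in this assay and nitro in place of methyl gave a 1.0-fold higher number from compound 1 to compound 3 (0.00 log units; within the scatter) on the same aromatic carbon. With a third group at this place, para to a large group, all three compounds still lie within the scatter of one another, so methyl, bromo and nitro cannot be told apart here. Going by these compounds, whether an amine or a carboxylic acid at this place would give a number beyond the scatter stays open. No measurement at hand offers an explanation for this result.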